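The source may report more compounds than this note shows. Statements on the series, on what has been measured and on what is new or still open speak of the compounds shown alone.

Measured so far:
Compound 1, `CSc1ccc(Nc2ncnc3sc(Nc4c(Cl)cccc4Cl)nc23)cc1`; in a functional assay on HEK293 cells for antagonist activity at transient receptor potential cation channel subfamily V member 1 (Rattus norvegicus), read by calcium flux (on this read-out higher numbers stand for weaker inhibition and lower numbers for stronger inhibition), compound 1 gives 12 nM.
Compound 2, `O=C(c1ccc(Nc2ncnc3sc(Nc4c(Cl)cccc4Cl)nc23)cc1)N1CCCC1`; in this assay compound 2 gives > 5000 nM, which is a limit of the assay and not a number.

Compound 2 stands at the weak end of the two values shown, and its step of an at least 410-fold higher number from compound 1 to compound 2 (2.61 log units; beyond the scatter) is the only measured one; its size rests on (the limit of > 5000 nM in this assay, at which 1 of the 2 values shown sits).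

Compound 3 is `O=S(=O)(c1ccc(Nc2ncnc3sc(Nc4c(Cl)cccc4Cl)nc23)cc1)N1CCCC1`. The change is (pyrrolidin-1-yl)sulfonyl in place of (pyrrolidin-1-yl)carbonyl on an aromatic carbon. Within the data shown here, no measured step bears on this exchange, so no step beyond the scatter is expected, a step that the limit leaves unreadable from compound 2 to compound 3. Compound 3 is therefore estimated at 8000 nM, within 1500 nM to 40000 nM, most likely again reported as a limit.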

Compound 3, half-maximal inhibitory concentration: 0.5 nM
Estimate against measurement, compound 3: 16000-fold (4.20 log units) above; the whole stated range lies above it.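

Keeping the pyrrolidine ring and exchanging only the carbonyl for sulfonyl gives an at least 10000-fold lower number from compound 2 to compound 3 (4.00 log units; beyond the scatter), so a pyrrolidine ring at this position does not by itself rule out strong inhibition. The sulfonyl group also outdoes methylsulfanyl, with a 24-fold lower number from compound 1 to compound 3 (1.38 log units; beyond the scatter). The value of compound 2 is a limit and not a number, so the first step has no exact size: the limit of > 5000 nM in this assay, at which 1 of the 3 values shown sits.

Open, from the compounds shown here alone, is whether this strength depends on the pyrrolidine ring, or also holds with morpholin-4-ylsulfonyl or methylsulfonyl on the same aromatic carbon.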